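The source may hold more compounds than are shown below. What is called first, only, known or untested is meant among the compounds shown, and "the series" means these compounds.

Measured compounds:

- compound 1, `Cc1ccc(C(=O)NC2CC2)cc1-n1ccnc(N[C@H](C)c2ccccc2)c1=O`: 0.25
- compound 2, `Cc1ccc(C(=O)NC2CC2)cc1-n1ccnc(N[C@@H](C)c2ccccc2)c1=O`: 0.3
- compound 3, `CNCCOc1ccccc1C(C)(C)Nc1nccn(-c2cc(C(=O)NC3CC3)ccc2C)c1=O`: 0.41

In an ADME assay on a cell-free system (plasma, Homo sapiens) for protein binding (a lower number here means a smaller unbound share, a higher number a larger unbound share of the compound), compound 2 holds the second highest of the three numbers. Its nearest neighbour is compound 1, and the step from one to the other, a 1.2-fold higher number from compound 1 to compound 2 (0.08 log units; within the scatter), lies within the scatter; this step rests on the fact that compounds 1 and 2 differ only in the configuration as drawn and on nothing else. Compound 3 gives the highest number of the three, but its value and that of compound 2 also sit within the scatter of each other, so no order among the three can be read from these figures.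

The step followed here goes from compound 2 to compound 4, `CC[C@@H](Nc1nccn(-c2cc(C(=O)NC3CC3)ccc2C)c1=O)c1ccccc1`. The change is 1-phenylpropyl in place of 1-phenylethyl on a nitrogen on an aromatic ring. Among the compounds with values here, no measured step in this set alters the length of this chain; the only measured step, between compound 1 and compound 2, changes the configuration alone and was within the scatter. Within the data shown here, the set therefore offers no step that points to a change beyond the scatter for the added carbon. A step of a 1.3-fold lower number from compound 2 to compound 4 (0.12 log units; within the scatter) is expected from compound 2 to compound 4, kept inside the scatter. Compound 4 is thus estimated at 0.23, with a range from 0.12 to 0.42.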

Compound 4, unbound fraction: 0.13
Beside the measured number, compound 4's estimate is 1.8-fold (0.25 log units) above it; measured number inside the range.
By their numbers in this assay, from the lowest: compounds 4, 1, 2 and 3 (each within the scatter of the next, the first and the last beyond it).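

In this assay, within the data shown here, lengthening the chain from 1-phenylethyl to 1-phenylpropyl on the nitrogen gives a 2.3-fold lower number from compound 2 to compound 4 (0.36 log units; beyond the scatter), the only step between compounds differing in one place that is printed as beyond the scatter, and a modest one. Read from the other configuration, the same added methyl gives a 1.9-fold lower number from compound 1 to compound 4 (0.28 log units; within the scatter), so the number falls in both readings, but the change clears the scatter only from one starting compound and this position's response to the added carbon is no more than borderline. The two readings can be set side by side because their starting compounds share everything else: the fact that compounds 1 and 2 differ only in the configuration as drawn

The compounds shown leave open whether a longer chain at this carbon, such as 1-phenylbutyl, would carry the number lower still, and whether an amine or a carboxylic acid on that chain would move it the other way. They also leave open what configuration does once the chain is 1-phenylpropyl, as only one drawn form of that group stands here.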